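Half-life notes on the shared core: compound 2 to compound 3

The source may hold more compounds than are shown below. What is called first, only, known or untested is meant among the compounds shown, and "the series" means these compounds.

Measured so far in an ADME assay for pharmacokinetics, in phosphate buffer; on this read-out higher numbers stand for a longer-lived compound and lower numbers for a shorter-lived compound:
compound 1 `CN(/N=N/c1nc(OCc2ccccc2)c2nc[nH]c2n1)C(=O)c1ccccc1` gives 38.3 h
compound 2 `CN(/N=N/c1nc(OCc2ccccc2)c2nc[nH]c2n1)C(=O)c1ccc([N+](=O)[O-])cc1` gives 16 h

For the measured compounds named here, compound 2 stands lowest of the two numbers in this assay; its nearest neighbour is compound 1, and the one step so far, a 2.4-fold lower number from compound 1 to compound 2 (0.38 log units; beyond the scatter), is the only measured change on the aromatic ring attached to the carbonyl carbon.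

Compound 3 `CN(/N=N/c1nc(OCc2ccccc2)c2nc[nH]c2n1)C(=O)c1cccnc1` is not yet measured. Its change from compound 2 is pyridin-3-yl in place of 4-nitrophenyl on a carbonyl carbon. Part of this change undoes the one step already seen: the nitro group leaves, and in this assay that nitro had given a 2.4-fold lower number from compound 1 to compound 2 (0.38 log units; beyond the scatter). Nothing measured bears on a pyridin-3-yl in this position, so that part of the change carries no evidence either way.

Taking the removal of the nitro as the informative part, compound 3 is expected to move back toward compound 1, so the step of a 1.8-fold higher number from compound 2 to compound 3 (0.24 log units; within the scatter) is expected, upward and modest. Compound 3 is therefore estimated at 28 h, within a range from 14 h to 56 h in this assay.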

Compound 3, half-life: 8.83 h
Beside the measured number, compound 3's estimate is 3.2-fold (0.50 log units) above it, outside the stated range (below it).
By their numbers in this assay, from the lowest: compounds 3 and 2 (each within the scatter of the next); then compound 1.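

Working notes on the aryl group on the carbonyl carbon: in this assay, pyridin-3-yl in place of 4-nitrophenyl gives a 1.8-fold lower number from compound 2 to compound 3 (0.26 log units; within the scatter), so the two groups cannot be told apart on this read-out. The comparison with the unsubstituted ring is clearer, as pyridin-3-yl in place of phenyl gives a 4.3-fold lower number from compound 1 to compound 3 (0.64 log units; beyond the scatter), which makes this the second change away from phenyl, after the nitro step, to end beyond the scatter and on the lower side; among the three compounds shown, none goes against this. Losing the nitro group therefore does not by itself bring the number back towards that of compound 1, and no measurement shown here accounts for the difference between the rings.

The two changes away from phenyl are single examples, so they do not show whether any other group on this carbonyl carbon would match or exceed compound 1, for instance a phenyl ring carrying an amine or a carboxylic acid, or a longer alkyl chain in place of the ring. All three compounds also share the benzyl ether and the rest of the core, so they say nothing about how changes there would affect the half-life.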